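Methylsulfanyl for hydroxy on a fused triazine core

This account rests on a few compounds, and the source may have more. Where it says the series, first, only, none or still open, it means among the compounds named here.

Compound 1, with the structure `CCCc1ncn2c(O)nncc12`, gives in a functional assay for inhibition, with Homo sapiens as the target (a lower number here means a stronger inhibitor, a higher number a weaker inhibitor), the value > 48000 nM, which is a limit of the assay and not a number.
Compound 2, with the structure `CCCc1ncn2c(SC)nncc12`, gives in this assay the value > 48000 nM, again a limit of the assay.
Compound 3, with the structure `CCc1nc(C)c2c(-c3ccccc3)nnc(O)n12`, gives in this assay the value > 48000 nM, also a limit of the assay.

The change from compound 1 to compound 2 is methylsulfanyl in place of hydroxy on an aromatic carbon. Its step in this assay is a step that the two limits leave unreadable from compound 1 to compound 2, because of the limit of > 48000 nM in this assay, at which 3 of the 3 values shown sit. Compound 4, with the structure `CCc1nc(C)c2c(-c3ccccc3)nnc(SC)n12`, is not yet measured; it carries the same kind of change on the core of compound 3, namely (methylsulfanyl in place of hydroxy on an aromatic carbon), the place differing only in that it is also para to a phenyl group. How the core of compound 3 differs from the core of compound 1 is not broken down here.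

Since the measured step from compound 1 to compound 2 cannot be read, the step from compound 3 to compound 4 in this assay is expected to be a step that the limit leaves unreadable from compound 3 to compound 4, resting on compound 3 sitting at > 48000 nM. Compound 4 is therefore estimated at 60000 nM, within 20000 nM to 200000 nM, most likely reported only as a limit.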

Compound 4, half-maximal inhibitory concentration: > 48000 nM
Compound 4: a limit, no number (the forecaster's own chance of this, stated with the estimate: 85%); the middle value does not contradict the limit.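

As with compound 3, the result for compound 4 in this assay is a limit of the assay and not a number, so the step between the two cannot be read, because every result so far stops at the same limit: the limit of > 48000 nM in this assay, at which 4 of the 4 values shown sit.

The compounds shown leave open how strong any of the four is as an inhibitor, and whether methylsulfanyl in place of hydroxy changes inhibition on either core.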